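Swapping a Fluorine Aryl for a Methoxy Aryl on a Shared Core

This account rests on a few compounds, and the source may have more. Where it says the series, first, only, none or still open, it means among the compounds named here.

Compound 1 `COc1cc(-c2ncnn2-c2cccc(N)c2)cc(OC)c1OC`: in a functional assay on MCF7 cells (Homo sapiens) for antiproliferative activity, read by MTT assay, with a stated time of 72 h (a lower number here means a stronger inhibitor, a higher number a weaker inhibitor), compound 1 gives > 10000 nM, a limit of the assay rather than a number.
Compound 2 `COc1cc(-n2ncnc2-c2ccc(F)cc2)cc(OC)c1OC`: in this assay compound 2 gives > 10000 nM, again a limit.
Compound 3 `COc1cc(-c2ncnn2-c2ccc([N+](=O)[O-])cc2)cc(OC)c1OC`: in this assay compound 3 gives > 10000 nM, again a limit.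

Compound 2 therefore has no measured number of its own; it stands at the ceiling of the assay, and so do the other two compounds, since (the limit of > 10000 nM in this assay, at which 3 of the 3 values shown sit). Every value is a limit. Among the measured compounds shown here, no step between the measured compounds can be sized, and none can be called stronger or weaker than another.

Compound 4 `COc1cccc(-c2ncnn2-c2cc(OC)c(OC)c(OC)c2)c1` is not yet measured. It differs from compound 2 in one place: 3-methoxyphenyl in place of 4-fluorophenyl on an aromatic carbon. Both compounds carry the same shared core, and both carry the same three methoxy groups on the other aryl ring.

With three compounds all at the limit, there is nothing to suggest that this change moves potency. The step from compound 2 to compound 4 is expected to be a step that the limit leaves unreadable from compound 2 to compound 4, that is, none beyond the scatter, and the assay is expected to report a limit again. Compound 4 is estimated to give 15000 nM, within a range from 5000 nM to 50000 nM.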

Compound 4, half-maximal inhibitory concentration: > 10000 nM
Compound 4 ended at the assay's limit; the forecaster's own chance of this, stated with the estimate: 85%; the middle value lies beyond the limit too.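

In this assay compound 4 gives > 10000 nM as a limit and not a number. Among the compounds shown here, compound 2 also sits at a limit, so no step between compound 2 and compound 4 can be read: the limit of > 10000 nM in this assay, at which 4 of the 4 values shown sit. The compounds shown leave open whether any change of aryl group on the shared core can bring a readable value.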